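Working notes: replacing the 2-methoxyphenyl group of compound 3

The compounds below may be only part of what the source reports. "The series", "measured", "known", "first", "only" and "open" are said of these compounds alone.

In a functional assay on MCF7 cells (Homo sapiens) for antiproliferative activity, read by MTT assay (on this read-out lower numbers stand for stronger inhibition and higher numbers for weaker inhibition), compound 1 (`COc1cc2c(Oc3ccc(NC(=O)Nc4ccccc4)cc3)ccnc2cc1OCCCCCCC(=O)NO`) gives 1040 nM, compound 2 (`COc1cc2c(Oc3ccc(NC(=O)Nc4ccc(C(F)(F)F)cc4Cl)cc3)ccnc2cc1OCCCCCCC(=O)NO`) gives 500 nM and compound 3 (`COc1ccccc1NC(=O)Nc1ccc(Oc2ccnc3cc(OCCCCCCC(=O)NO)c(OC)cc23)cc1`) gives 6280 nM, the highest of the three numbers. Compound 4 (`COc1cc2c(Oc3ccc(NC(=O)NNC(=O)c4ccccc4F)cc3)ccnc2cc1OCCCCCCC(=O)NO`) has ((2-fluorophenyl)carbonyl)amino in place of 2-methoxyphenyl on an amide-type nitrogen. The measured changes at this nitrogen are a 2.1-fold lower number from compound 1 to compound 2 (0.32 log units; beyond the scatter), a 6.0-fold higher number from compound 1 to compound 3 (0.78 log units; beyond the scatter) and a 13-fold higher number from compound 2 to compound 3 (1.10 log units; beyond the scatter), so they range from modest to large. None brings in a carbonyl-bearing group, which leaves the direction uncertain. Since compound 3 already sits highest at 6280 nM, a modest fall is the more likely outcome. The expected step is a 3.1-fold lower number from compound 3 to compound 4 (0.50 log units; beyond the scatter). The estimate for compound 4 is 2000 nM, with an expected range of 600 nM to 7000 nM.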

Compound 4, half-maximal inhibitory concentration: 3600 nM
Beside the measured number, compound 4's estimate is 1.8-fold (0.26 log units) below it, within the range that was stated.
By their numbers in this assay, from the lowest: compound 2; then compound 1; then compounds 4 and 3 (each within the scatter of the next).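

In this assay, within the data shown here, ((2-fluorophenyl)carbonyl)amino, the only carbonyl-bearing group at this amide-type nitrogen, does not separate from 2-methoxyphenyl, with a 1.7-fold lower number from compound 3 to compound 4 (0.24 log units; within the scatter). It still leaves the number higher than phenyl and 2-chloro-4-(trifluoromethyl)phenyl do, with a 3.5-fold higher number from compound 1 to compound 4 (0.54 log units; beyond the scatter) and a 7.2-fold higher number from compound 2 to compound 4 (0.86 log units; beyond the scatter). No available evidence bears on these steps.

The compounds shown leave open what the carbonyl and the fluorine each contribute. A benzoylamino group without fluorine and a benzylamino group without the carbonyl would separate the two.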